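The compounds below may be only part of what the source reports. "The series", "measured", "known", "first", "only" and "open" are said of these compounds alone.

For the measured compounds named here, both compounds measured so far were tested in a functional assay on MCF7 cells (Homo sapiens) for cytotoxicity, read by MTT assay, with a stated time of 24 h; a lower number here means a stronger inhibitor, a higher number a weaker inhibitor. Compound 1 `CCCCC(=O)NC(=S)Nc1nc2cc(N)ccc2s1` gives 44700 nM in this assay. Compound 2 `Nc1ccc2sc(NC(=S)NC(=O)N3CCOCC3)nc2c1` gives 26400 nM in this assay. Going by the values given here, the only step between measured compounds, a 1.7-fold lower number from compound 1 to compound 2 (0.23 log units; within the scatter), swaps morpholin-4-yl for butyl on a carbonyl carbon, and since that step is within the scatter, the two compounds sit together on the scale, with compound 1 carrying the larger of the two numbers recorded.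

Compound 3 `CCCCC(=O)NC(=S)Nc1nc2ccccc2s1` differs from compound 1 in a different part of the molecule: hydrogen in place of amino on an aromatic carbon. The measured step from compound 1 to compound 2 touches the carbonyl side, not the aromatic ring, so it gives no guidance on what removing the amino group does here. Among the compounds with values here, with no step bearing on this change, the plain expectation is that the step of a 1.1-fold lower number from compound 1 to compound 3 (0.05 log units; within the scatter) stays within the scatter. Compound 3 is therefore estimated at 40000 nM in this assay, with a range from 13000 nM to 120000 nM.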

Compound 3, half-maximal inhibitory concentration: 36600 nM
The estimate for compound 3 lay 1.1-fold (0.04 log units) above the measured number; low and high end bracket the measured number.
By their numbers in this assay, from the lowest: compounds 2, 3 and 1 (each within the scatter of the next).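

In this assay the record shows a 1.2-fold lower number from compound 1 to compound 3 (0.09 log units; within the scatter) when hydrogen replaces amino on an aromatic carbon, and this step lies within the scatter. For the compounds shown here, the earlier pair spoke only to the carbonyl side, so this is the first reading at the aromatic ring: with butyl on the carbonyl carbon, the amino group, with its one nitrogen, can give way to hydrogen without the number moving beyond the scatter. No measurement offered here explains this result or bears on it.

From the compounds shown here alone, only amino and hydrogen have been compared at this carbon, so it remains open whether a different group there, such as a methoxy group, a chlorine atom or a carboxylic acid, would move the number beyond the scatter. Also open, going by these compounds, is whether the same swap of amino for hydrogen would read alike with morpholin-4-yl on the carbonyl carbon, as in compound 2.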